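The source may report more compounds than this note shows. Statements on the series, on what has been measured and on what is new or still open speak of the compounds shown alone.

Measured in a functional assay on P388 cells (Mus musculus) for cytotoxicity; on this read-out higher numbers stand for weaker inhibition and lower numbers for stronger inhibition:
- compound 1 `Cc1cc(-c2c(F)cc3c(=O)c(Cc4ccc(Cl)cc4)cn(C4CC4)c3c2F)cc(C)n1`: 20000 nM
- compound 2 `Cc1cc(-c2c(F)cc3c(=O)c(Cc4ccccc4O)cn(C4CC4)c3c2F)cc(C)n1`: 670 nM

For the measured compounds named here, compound 2, at 670 nM, holds the lower of the two numbers in this assay, and compound 1, at 20000 nM, is its only comparison.

The next compound is compound 3 `Cc1cc(-c2c(F)cc3c(=O)c(Cc4ccccc4)cn(C4CC4)c3c2F)cc(C)n1`, which carries hydrogen in place of hydroxy on an aromatic carbon, taking 2-hydroxyphenyl to phenyl. Going by the values given here, one measured step bears on this: a 30-fold lower number from compound 1 to compound 2 (1.47 log units; beyond the scatter), a large step that exchanges 4-chlorophenyl for 2-hydroxyphenyl. That step alters two substituents together. Among the compounds with values here, no measured step removes the hydroxy alone, and the unsubstituted phenyl has no measured value to anchor it. Compound 3 lacks both the chloro and the hydroxy substituent, so it is expected to fall inside the span set by the two measured compounds, with the number rising from the lower end. A step beyond the scatter is expected, though smaller than the one already measured. The estimated change is a 7.5-fold higher number from compound 2 to compound 3 (0.87 log units; beyond the scatter). For compound 3 the expected value is 5000 nM, with an estimated range of 1500 nM to 20000 nM.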

Compound 3, half-maximal inhibitory concentration: 7300 nM
Estimate against measurement, compound 3: 1.5-fold (0.16 log units) below; the range from low to high includes it.
By their numbers in this assay, from the lowest: compound 2; then compound 3; then compound 1.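

In this assay the hydroxy can now be read on its own: taking it away from the 2-hydroxybenzyl group gives an 11-fold higher number from compound 2 to compound 3 (1.04 log units; beyond the scatter), a large step that accounts for most of the earlier combined exchange, a 30-fold lower number from compound 1 to compound 2 (1.47 log units; beyond the scatter). Compound 3 also separates the chloro from the hydroxy, and removing the chloro gives a 2.7-fold lower number from compound 1 to compound 3 (0.44 log units; beyond the scatter), a modest step beyond the scatter, so the two substituents move the number in opposite directions from the unsubstituted benzyl, with the larger change coming from the hydroxy. Nothing available explains either step.

Still open, on these data alone, is whether the lower number depends on the hydroxy itself, which an amine or a methoxy group on the same aromatic carbon would test, and whether a hydroxy elsewhere on the ring would give a similar step. Also unresolved is whether the two steps would simply add in a ring carrying both chloro and hydroxy, since the compounds here show each substituent only alone.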